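From 4-methylphenyl to 2-bromophenyl in a cytotoxicity series

This account rests on a few compounds, and the source may have more. Where it says the series, first, only, none or still open, it means among the compounds named here.

In an ADME assay on HEK293 cells (Homo sapiens) for cytotoxicity, read by MTT assay, with a stated time of 72 h (on this read-out higher numbers stand for weaker inhibition and lower numbers for stronger inhibition), compound 3 (`Cc1ccc(C(=O)N2CCN(CC(=O)N3CCN(CCCc4c[nH]c5ccc(F)cc45)CC3)CC2)cc1`) gives 141000 nM. That sits within the scatter of compound 1 (`Cc1ccc(C(=O)N2CCN(CC(=O)N3CCN(CCCc4c[nH]c5ccccc45)CC3)CC2)cc1`), which gives 159000 nM. Compound 2 (`O=C(CN1CCN(C(=O)c2ccc(Br)cc2)CC1)N1CCN(CCCc2c[nH]c3ccc(F)cc23)CC1`) gives 60500 nM in the same test, a lower number than that of compound 3.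

Compound 4 (`O=C(CN1CCN(C(=O)c2ccccc2Br)CC1)N1CCN(CCCc2c[nH]c3ccc(F)cc23)CC1`) differs from compound 3 in one group, with 2-bromophenyl in place of 4-methylphenyl on a carbonyl carbon. The fluoro in place of hydrogen on an aromatic carbon (a 1.1-fold lower number from compound 1 to compound 3 (0.05 log units; within the scatter)) is a change elsewhere in the molecule and does not bear on this one. The closer guide is methyl in place of bromo on an aromatic carbon (a 2.3-fold higher number from compound 2 to compound 3 (0.37 log units; beyond the scatter)). Read backwards, that step points toward a lower number for a bromo compound, but the bromo of compound 4 does not sit where the bromo of compound 2 sits, and no measured compound shows the new placement. A somewhat smaller step toward a lower number is therefore expected in this assay (a 1.8-fold lower number from compound 3 to compound 4 (0.25 log units; within the scatter)). Compound 4 is estimated at 80000 nM (expected range 35000 nM to 160000 nM).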

Compound 4, half-maximal inhibitory concentration: 77100 nM
Compound 4: middle estimate off by 1.0-fold (0.02 log units), on the high side, within the range that was stated.
By their numbers in this assay, from the lowest: compounds 2, 4, 3 and 1 (each within the scatter of the next, the first and the last beyond it).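

Moving the bromo to the new placement on this carbonyl carbon does not separate the two bromo compounds in this assay, with a 1.3-fold higher number from compound 2 to compound 4 (0.11 log units; within the scatter). The 2-bromophenyl compound also stays within the scatter of the 4-methylphenyl compound, with a 1.8-fold lower number from compound 3 to compound 4 (0.26 log units; within the scatter), so compound 4 cannot be told apart from either neighbour, although compound 2 and compound 3 are separated by a step beyond the scatter. No measurement offered here accounts for these numbers.

Going by these compounds, what remains open is how a 2-methylphenyl group would read on this carbonyl carbon, which would show the effect of placement for methyl as well as for bromo. On these data alone, the reading of a phenyl ring carrying an amine or a carboxylic acid at this position also remains open.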